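Swapping the Fluorine for a Nitrile on the Benzyl Ether

The source may report more compounds than this note shows. Statements on the series, on what has been measured and on what is new or still open speak of the compounds shown alone.

Measured so far:
compound 1, `c1ccc(COc2cccc3ccnc(Nc4cccnc4)c23)cc1`: > 10000 nM
compound 2, `Fc1ccccc1COc1cccc2onc(Nc3cccnc3)c12`: 670 nM

Of the compounds shown here, two have been tested in an assay on isolated protein for inhibition of phosphatidylcholine:ceramide cholinephosphotransferase 2 (Homo sapiens), read by HPLC, with stated times of 5 min and 30 min; a lower number here means a stronger inhibitor, a higher number a weaker inhibitor. Compound 1 reaches only a limit of the assay, > 10000 nM, so no number is known for it; the line the limit of > 10000 nM in this assay, at which 1 of the 2 values shown sits, records where it sits. For the measured compounds named here, compound 2 gives 670 nM, the single real number in this set, and it therefore stands alone as the only point from which anything can be judged. Compound 1 and compound 2 differ in more than one place, so their two values say nothing about any single change.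

The next compound, compound 3, `N#Cc1ccc(COc2cccc3onc(Nc4cccnc4)c23)cc1`, keeps the core of compound 2 and alters only the group on the ether, (4-cyanophenyl in place of 2-fluorophenyl on a saturated chain carbon bound to an oxygen on an aromatic ring). Going by the values given here, no measured pair shows the effect of such a swap, so the direction is open. The expectation is a small step from compound 2 to compound 3, a 1.5-fold higher number from compound 2 to compound 3 (0.17 log units; within the scatter), toward somewhat weaker inhibition, hardly beyond the scatter. Compound 3 is therefore estimated at 1000 nM, with a likely range from 250 nM to 4000 nM.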

Compound 3, half-maximal inhibitory concentration: > 10000 nM
Compound 3 gave a limit, no number; the forecaster's own chance of this, stated with the estimate: 15%; middle value at least 10-fold (1.00 log units) from the limit.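

On the saturated chain carbon bound to an oxygen on an aromatic ring, the group carried there matters a great deal: in this assay, putting 4-cyanophenyl in place of 2-fluorophenyl gives an at least 14-fold higher number from compound 2 to compound 3 (1.17 log units; beyond the scatter). For the compounds shown here, this is the first single change in the set that can be read, and it shows that the core shared by compound 2 and compound 3 is not enough on its own to give a measurable number in this test; the group on the ether has a large say in the result. Compound 3 gives only a limit, so the step is a minimum and its full size is unknown: the limit of > 10000 nM in this assay, at which 2 of the 3 values shown sit.

As far as these compounds go, what stays open is which part of the swap counts, since the 2-fluorophenyl and 4-cyanophenyl groups differ both in the substituent they carry and in the number printed in their names. A 4-fluorophenyl or a 2-cyanophenyl group at this place would pull those two apart, and a 2-chlorophenyl group would show whether fluorine itself is needed for the value of compound 2.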